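One Methyl Removed and a Cytotoxicity Read-Out

The source may hold more compounds than are shown below. What is called first, only, known or untested is meant among the compounds shown, and "the series" means these compounds.

Compound 1 `COc1cc(/C=N/NC(=O)c2ccncc2)cc(OC)c1O`: 65%
Compound 2 `COc1cc(/C=N/NC(=O)c2ccncc2)cc(OC)c1OC`: 4%
Compound 3 `COc1cc(/C=N/NC(=O)OCc2ccccc2)ccc1O`: 73%

In a functional assay on cells (Mus musculus) for cytotoxicity, read by MTT assay, with a stated time of 24 h, tested at 10 uM (on this read-out higher numbers stand for a stronger effect at the one concentration tested and lower numbers for a weaker effect), compound 3 and compound 1 lie within the scatter of each other, while compound 2 lies far lower. For the measured compounds named here, the one change from compound 2 to compound 1 is hydrogen in place of methyl on an oxygen on an aromatic ring, and it made a number 61 percentage points higher from compound 2 to compound 1 (beyond the scatter). How the core of compound 3 differs from that of compound 2 is not broken down here. Compound 4 `O=C(N/N=C/c1ccc(O)c(O)c1)OCc1ccccc1` differs from compound 3 by hydrogen in place of methyl on an oxygen on an aromatic ring, the same change. Since compound 3 already gives 73%, the room upward is small, so compound 4 is expected to rise by a number 7 percentage points higher from compound 3 to compound 4 (within the scatter), a much smaller step than a number 61 percentage points higher from compound 2 to compound 1 (beyond the scatter). Compound 4 is estimated at 80%, between 62% and 94%.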

Compound 4, a percentage reported as activity, at one concentration (the size of the read-out at that concentration, not a potency): 84%
The estimate for compound 4 lay 4 percentage points below the measured number; the range from low to high includes it.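

In this assay the change from methoxy to hydroxy gave a number 11 percentage points higher from compound 3 to compound 4 (beyond the scatter) and so pointed the same way on both cores. The direction carried over between these two pairs, but the size of the step did not: the same change on two cores in this assay, a number 61 percentage points higher (beyond the scatter) from compound 2 to compound 1 and a number 11 percentage points higher (beyond the scatter) from compound 3 to compound 4, 50 percentage points apart, beyond the scatter of two such steps

Two pairs cannot show which difference between the cores sets the size of the step, or whether the direction would hold on a further core.

The compounds shown leave open what an ethyl or acetyl group would do on that oxygen in place of the methyl, and what an amine would do on the aromatic ring in place of the hydroxy. From the compounds shown here alone, whether the two steps would keep their sizes at other concentrations also stays open.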